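The compounds below may be only part of what the source reports. "The series", "measured", "known", "first", "only" and "open" are said of these compounds alone.

Of the compounds shown here, three have so far been tested in an ADME assay on CCRF-CEM cells (Homo sapiens) for cytotoxicity, read by trypan blue exclusion, with a stated time of 6 days; on this read-out higher numbers stand for lower toxicity in this test and lower numbers for higher toxicity in this test. Compound 1 `COc1nc(ONC(=O)OCc2ccccc2)nc2c1ncn2[C@@H]1O[C@H](CO)[C@@H](O)[C@@]1(C)O` carries a (benzyloxycarbonyl)amino group on an oxygen on an aromatic ring. In this assay compound 1 gives only a limit, > 100000 nM. Compound 2 `COc1nc(O)nc2c1ncn2[C@@H]1O[C@H](CO)[C@@H](O)[C@@]1(C)O` differs from compound 1 by hydrogen in place of (benzyloxycarbonyl)amino on an oxygen on an aromatic ring, and this is also how its core differs from that of compound 1. In this assay compound 2 likewise gives a limit, > 100000 nM. Compound 3 `C[C@@]1(O)[C@H](O)[C@@H](CO)O[C@H]1n1cnc2c(N)nc(ONC(=O)OCc3ccccc3)nc21` differs from compound 1 by amino in place of methoxy on an aromatic carbon. In this assay compound 3 gives a limit as well, > 100000 nM. The step that the two limits leave unreadable from compound 1 to compound 2 and the step that the two limits leave unreadable from compound 1 to compound 3 cannot be sized, since (the limit of > 100000 nM in this assay, at which 3 of the 3 values shown sit).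

Compound 4 `C[C@@]1(O)[C@H](O)[C@@H](CO)O[C@H]1n1cnc2c(N)nc(O)nc21` is not yet measured; it differs from compound 2 by amino in place of methoxy on an aromatic carbon. This is the same kind of change as that from compound 1 to compound 3, though the surroundings are not identical: in compound 3 the changed carbon is meta to a large group, whereas in compound 4 it is meta to a hydroxy group (1 heavy atom). The step from compound 2 to compound 4 is expected to be a step that the limit leaves unreadable from compound 2 to compound 4, resting on the step that the two limits leave unreadable from compound 1 to compound 3 from compound 1. Compound 4 is thus estimated at about 150000 nM, between 60000 nM and 400000 nM.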

Compound 4, half-maximal cytotoxic concentration: > 100000 nM
Compound 4: a limit, no number; the forecaster's own chance of this, stated with the estimate: 80%; the middle value is on the limit's open side.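

In this assay compound 4 gives > 100000 nM which is a limit and not a number. No step can be read between compound 2 and compound 4, since both give only limits: the limit of > 100000 nM in this assay, at which 4 of the 4 values shown sit. The compounds shown leave open how large any of these changes is and at what concentration any of the four compounds harms these cells.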